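Purine acyclic nucleosides: methylamino replaces iodo on the core

The source may report more compounds than this note shows. Statements on the series, on what has been measured and on what is new or still open speak of the compounds shown alone.

Measured in a functional assay on L1210 cells (Mus musculus) for inhibition; a lower number here means a stronger inhibitor, a higher number a weaker inhibitor:
compound 1 `O=c1cc(O)ccn1COCCO` — > 1000 ug/mL
compound 2 `Nc1nc2c(nc(Cl)n2COCCO)c(=O)[nH]1` — > 1000 ug/mL
compound 3 `Nc1nc2c(nc(I)n2COCCO)c(=O)[nH]1` — > 1000 ug/mL

Each of these three values is a limit of this assay, not a number. Compound 3 therefore stands at the top limit, where all three compounds sit (the limit of > 1000 ug/mL in this assay, at which 3 of the 3 values shown sit). For the measured compounds named here, the one step between measured compounds that differ in a single place, a step that the two limits leave unreadable from compound 2 to compound 3, is hidden by the two limits, so its size cannot be read.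

Compound 4 `CNc1nc2c(=O)[nH]c(N)nc2n1COCCO` is not yet measured. It differs from compound 3 by methylamino in place of iodo on an aromatic carbon.

Going by the values given here, no measured step bears readably on this change: the only step, from a halogen to a halogen, is unreadable, and no compound with a methylamino group in this place has a value. Among the compounds with values here, the only guidance is that every value shown sits at the limit (the limit of > 1000 ug/mL in this assay, at which 3 of the 3 values shown sit). The expected step, a step that the limit leaves unreadable from compound 3 to compound 4, is estimated without any measured guidance on its size or direction. Compound 4 is therefore expected to give about 1500 ug/mL in this assay, within a range from 300 ug/mL to 5000 ug/mL, most likely reported again as a limit only.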

Compound 4, concentration for 50% inhibition: > 500 ug/mL
Compound 4: a limit, no number (the forecaster's own chance of this, stated with the estimate: 80%); the middle value does not contradict the limit.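

In this assay compound 4 gives > 500 ug/mL, a limit and not a number. Compound 3 also gives only a limit, > 1000 ug/mL, so the steps from compound 2 and compound 3 to compound 4 cannot be read. The compounds shown leave open whether methylamino differs from iodo or chloro at this place in inhibition.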